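Iodo for Methoxycarbonyl: an Expected Return of Potency

The compounds below may be only part of what the source reports. "The series", "measured", "known", "first", "only" and "open" are said of these compounds alone.

Compound 1 `O=C(CCCCCCc1ccccc1)c1nc(-c2cccc(Br)n2)no1`: 2040 nM
Compound 2 `COC(=O)c1cccc(-c2noc(C(=O)CCCCCCc3ccccc3)n2)n1`: > 10000 nM

In an assay on HEK-293T cells for inhibition of diacylglycerol lipase-alpha (Homo sapiens), read by colorimetric assay (a higher number here means a weaker inhibitor, a lower number a stronger inhibitor), compound 1 gives 2040 nM. For compound 2 this assay reports only a limit, (the limit of > 10000 nM in this assay, at which 1 of the 2 values shown sits), so its true number is not known. Among the compounds with values here, the single measured step, an at least 4.9-fold higher number from compound 1 to compound 2 (0.69 log units; beyond the scatter), shows that putting methoxycarbonyl where bromo stood weakened inhibition clearly. Compound 3 `O=C(CCCCCCc1ccccc1)c1nc(-c2cccc(I)n2)no1` differs from compound 2 by iodo in place of methoxycarbonyl on an aromatic carbon, which largely reverses that step with a related halogen. Because compound 1 gave 2040 nM with bromo in that place, compound 3 is expected to land near 1800 nM, between 600 nM and 6000 nM. The expected step is an at least 5.5-fold lower number from compound 2 to compound 3 (0.74 log units; beyond the scatter).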

Compound 3, half-maximal inhibitory concentration: > 10000 nM
Compound 3: no number, only a limit; the forecaster's own chance of this, stated with the estimate: 10%; at least 5.5-fold (0.74 log units) between middle value and limit.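

Iodo in place of bromo gave an at least 4.9-fold higher number from compound 1 to compound 3 (0.69 log units; beyond the scatter) and so showed that this position does not accept every halogen alike. Among the three compounds, only bromo here gives a readable number. Compound 2 and compound 3 each sit at a limit, and the step between them cannot be read: the limit of > 10000 nM in this assay, at which 2 of the 3 values shown sit.

On these data alone, how far either compound lies past that limit stays open. So does whether chloro, fluoro or an amine at this position would give a readable number, as bromo does.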